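This account rests on a few compounds, and the source may have more. Where it says the series, first, only, none or still open, it means among the compounds named here.

Compound 1, `CC1=NN(C(=O)/C=C/c2ccccc2)C(c2ccccc2O)C1`: in a functional assay on PC-3 cells (Homo sapiens) for cytotoxicity, read by MTT assay, with a stated time of 48 h (a lower number here means a stronger inhibitor, a higher number a weaker inhibitor), compound 1 gives 42000 nM.
Compound 2, `CC1=NN(C(=O)COc2ccc(Cl)cc2)C(c2ccccc2O)C1`: in this assay compound 2 gives 38800 nM.
Compound 3, `CC1=NN(C(=O)CCl)C(c2cc(Br)ccc2O)C1`: in this assay compound 3 gives 8890 nM.

All three compounds share one core and differ in the group on the ring nitrogen and in whether the phenol ring carries a bromo. Compound 2 stands among the two weaker inhibitors: its number and that of compound 1 lie within the scatter of each other, so no order can be read between them, while compound 3 sits well lower, beyond the scatter. Compound 3, however, differs from compound 2 in two places at once, so its lower number cannot be pinned to either change alone.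

Compound 4, `CC1=NN(C(=O)COc2ccc(Cl)cc2)C(c2cc(Br)ccc2O)C1`, is the next step from compound 2: bromo in place of hydrogen on an aromatic carbon. For the measured compounds named here, no pair of measured compounds isolates this change, so the expected size of the step in this assay rests only on the rough hint from compound 3. A moderate move toward a lower number is expected, with room for it to fall within the scatter. For compound 4 the estimated step is a 1.9-fold lower number from compound 2 to compound 4 (0.29 log units; within the scatter). Compound 4 is expected to give about 20000 nM, within a range of 7000 nM to 50000 nM.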

Compound 4, half-maximal inhibitory concentration: 49000 nM
Compound 4: the middle estimate sits 2.5-fold (0.39 log units) below what was measured, within the range that was stated.
By their numbers in this assay, from the lowest: compound 3; then compounds 2, 1 and 4 (each within the scatter of the next).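

In this assay, bromo in place of hydrogen on the aromatic carbon para to a hydroxy group gives a 1.3-fold higher number from compound 2 to compound 4 (0.10 log units; within the scatter), so with the 4-chlorophenoxy side chain in place, this change cannot be told apart from the usual scatter. The other new comparison holds the bromo fixed and changes only the side chain: 4-chlorophenoxy in place of chloro on the saturated chain carbon bound to the carbonyl carbon gives a 5.5-fold higher number from compound 3 to compound 4 (0.74 log units; beyond the scatter), which separates the two compounds clearly and ties the lower number of compound 3 to its chloro side chain rather than to its bromo, at least among these compounds. Nothing available here explains the size of either step.

From the compounds shown here alone, whether the bromo would also make so little difference with the chloro side chain remains open, since only the 4-chlorophenoxy series gives a direct reading of that change. Also open, going by these compounds, is how an amine or a methoxy group at the bromo position, or a longer carbon chain in place of the chloro, would read in this assay.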